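Smaller, Hydroxylated Side Chain in Place of sec-Butyl

This account rests on a few compounds, and the source may have more. Where it says the series, first, only, none or still open, it means among the compounds named here.

In a functional assay on A549 cells (Homo sapiens) for cytotoxicity, read by MTT assay, with a stated time of 24 h (on this read-out higher numbers stand for weaker inhibition and lower numbers for stronger inhibition), compound 1 `CC[C@H](C)[C@@H](NC(=O)Cn1cc(C2=C(c3c[nH]c4ccccc34)C(=O)N(C)C2=O)c2ccccc21)C(=O)OC` gives > 100000 nM, and this is a limit of the assay rather than a measured number. Within the data shown here, compound 1 is the one compound of the three that sits at the limit of > 100000 nM in this assay, at which 1 of the 3 values shown sits. Compound 2 `COC(=O)[C@H](NC(=O)Cn1cc(C2=C(c3c[nH]c4ccccc34)C(=O)N(C)C2=O)c2ccccc21)[C@@H](C)O` gives 25700 nM in this assay. Compound 3 `COC(=O)[C@H](NC(=O)Cn1cc(C2=C(c3c[nH]c4ccccc34)C(=O)N(C)C2=O)c2ccccc21)C(C)C` gives 30600 nM in this assay.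

Compound 4 `COC(=O)[C@@H](CO)NC(=O)Cn1cc(C2=C(c3c[nH]c4ccccc34)C(=O)N(C)C2=O)c2ccccc21` has not yet been measured. It differs from compound 1 in one place: hydroxymethyl in place of sec-butyl on a saturated chain carbon bound to an amide-type nitrogen and a carbonyl carbon.

Among the measured compounds shown here, two measured steps bear on this change. an at least 3.8-fold lower number from compound 1 to compound 2 (0.59 log units; beyond the scatter) shows that a hydroxy on the side chain brings the number off the limit. an at least 3.2-fold lower number from compound 1 to compound 3 (0.51 log units; beyond the scatter) shows that removing a methyl from the side chain does the same. Between those two products there is a 1.2-fold higher number from compound 2 to compound 3 (0.08 log units; within the scatter). Compound 4 combines both kinds of change: its side chain is shorter than in compound 1 and carries a hydroxy. A downward step off the limit, of about the size seen for compound 2 and compound 3, is therefore expected, with some chance that the assay again reports only a limit. Compound 4 is expected to give 28000 nM in this assay, within 10000 nM to 90000 nM. This estimate corresponds to an at least 3.5-fold lower number from compound 1 to compound 4 (0.55 log units; beyond the scatter).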

Compound 4, half-maximal inhibitory concentration: 37900 nM
Compound 4: the middle estimate sits 1.4-fold (0.13 log units) below what was measured; measured number inside the range.
By their numbers in this assay, from the lowest: compounds 2, 3 and 4 (each within the scatter of the next). At a limit, above all of these: compound 1.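

The value of compound 1, > 100000 nM, is a limit and not a number. In this assay, hydroxymethyl in place of sec-butyl gives an at least 2.6-fold lower number from compound 1 to compound 4 (0.42 log units; beyond the scatter), while the other two steps, a 1.2-fold higher number from compound 3 to compound 4 (0.09 log units; within the scatter) and a 1.5-fold higher number from compound 2 to compound 4 (0.17 log units; within the scatter), show that hydroxymethyl, isopropyl and 1-hydroxyethyl cannot be told apart here, so a hydroxy does not separate these three side chains, since isopropyl has none and still falls with the two that carry one. Taking away one methyl therefore has a different outcome on sec-butyl than on 1-hydroxyethyl: the same change on two cores in this assay, an at least 3.2-fold lower number (0.51 log units; beyond the scatter) from compound 1 to compound 3 and a 1.5-fold higher number (0.17 log units; within the scatter) from compound 2 to compound 4, at least 4.8-fold (0.68 log units) apart, beyond the scatter of two such steps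

The compounds shown leave open how far compound 1 truly lies from the other three, and whether the difference belongs to sec-butyl alone or would also appear with another longer chain, such as n-butyl, or with a benzyl group. They also leave open whether an amine or a carboxylic acid on this side chain would move the number beyond the scatter of the three values that now sit together.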